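The compounds below may be only part of what the source reports. "The series", "measured", "known", "first", "only" and "open" are said of these compounds alone.

Measured compounds:
compound 1 `CCCn1c(=O)[nH]c2nc(-c3ccc(S(=O)(=O)N4CCN(c5ccc(Cl)cc5F)CC4)cc3)[nH]c2c1=O` — 14%
compound 2 `CCCn1c(=O)[nH]c2nc(-c3ccc(S(=O)(=O)N4CCN(c5ccccc5C)CC4)cc3)[nH]c2c1=O` — 25%
compound 3 `CCCn1c(=O)[nH]c2nc(-c3ccc(S(=O)(=O)N4CCN(Cc5ccc(Br)c(F)c5)CC4)cc3)[nH]c2c1=O` — 27%

In an assay on CHO cells for displacement of a labelled ligand from adenosine receptor A3 (Homo sapiens), read by scintillation counting, with a stated time of 45 min, tested at 1 uM, in the presence of a further agent that is not named here (on this read-out lower numbers stand for less inhibition and higher numbers for more inhibition at the one concentration tested (going by the name of the read-out)), compound 2 stands second highest of the three. Its nearest neighbour is compound 3, with a number 2 percentage points higher from compound 2 to compound 3 (within the scatter), a gap within the scatter; its furthest is compound 1, with a number 11 percentage points higher from compound 1 to compound 2 (beyond the scatter). The other measured step, a number 13 percentage points higher from compound 1 to compound 3 (beyond the scatter), is of similar size.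

Compound 4 `CCCn1c(=O)[nH]c2nc(-c3ccc(S(=O)(=O)N4CCN(c5ccccc5Cl)CC4)cc3)[nH]c2c1=O` differs from compound 2 in one place: chloro in place of methyl on an aromatic carbon. Among the measured compounds shown here, no measured step matches this change directly. The two steps beyond the scatter, from compound 1, both replace the whole group on the amine nitrogen in the ring, while the step from compound 2 to compound 3 swaps one such group for another and stays within the scatter. A change of a single substituent on an aromatic carbon is smaller than any of these, so the step of no change at the digits printed from compound 2 to compound 4 (within the scatter) is expected to stay within the scatter, with no clear direction. Compound 4 is therefore estimated at 25%, in the range 12% to 40%.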

Compound 4, a percentage reported as inhibition, at one concentration (the size of the read-out at that concentration, not a potency): 32%
Estimate against measurement, compound 4: 7 percentage points below, within the range that was stated.
By their numbers in this assay, from the lowest: compound 1; then compounds 2, 3 and 4 (each within the scatter of the next).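

On the aromatic carbon ortho to a large group, chloro and methyl, each a single heavy atom, cannot be told apart in this assay (a number 7 percentage points higher from compound 2 to compound 4 (within the scatter)). The 2-chlorophenyl group likewise stays level with the 4-bromo-3-fluorobenzyl group (a number 5 percentage points higher from compound 3 to compound 4 (within the scatter)), yet it stands clear of the 4-chloro-2-fluorophenyl group (a number 18 percentage points higher from compound 1 to compound 4 (beyond the scatter)), which leaves compound 1 apart from the other three compounds. Nothing available offers an explanation for these numbers.

The compounds shown leave open whether another group on this aromatic carbon, such as methoxy, trifluoromethyl or an amine, would move the number beyond the scatter. They also leave open how these compounds compare in potency, since each percentage describes a single concentration.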